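Dimethylamino for methoxy on the furanyl nucleosides

The source may report more compounds than this note shows. Statements on the series, on what has been measured and on what is new or still open speak of the compounds shown alone.

Compound 3 `COc1ncnc2c1c(-c1ccoc1)cn2[C@@H]1O[C@H](CO)[C@@H](O)[C@H]1O` carries a methoxy group and a furan substituent on the shared core. In a functional assay on CEM-DNR-bulk cells (Homo sapiens), read by MTT assay, with a stated time of 72 h (a higher number here means a weaker inhibitor, a lower number a stronger inhibitor), compound 3 gives only a limit, > 20000 nM. Compound 2 `CNc1ncnc2c1c(-c1ccoc1)cn2[C@@H]1O[C@H](CO)[C@@H](O)[C@H]1O` is the methylamino counterpart of compound 3. In this assay compound 2 likewise gives only a limit, > 20000 nM. The step that the two limits leave unreadable from compound 2 to compound 3 is therefore not readable. Two of the three values shown sit at the limit of > 20000 nM in this assay, at which 2 of the 3 values shown sit, so compound 3 stands at the unresolved end of the series, with no number of its own. Within the data shown here, compound 1 `C#Cc1cn([C@@H]2O[C@H](CO)[C@@H](O)[C@H]2O)c2ncnc(N(C)C)c12`, which carries a dimethylamino group but an ethynyl substituent in place of the furan, gives 240 nM in this assay; no single-change step connects it to compound 3, so its value shows only that the core itself can be measured. Compound 4 `CN(C)c1ncnc2c1c(-c1ccoc1)cn2[C@@H]1O[C@H](CO)[C@@H](O)[C@H]1O` is the subject: dimethylamino in place of methoxy on an aromatic carbon. Among the measured compounds shown here, the only measured step on the furanyl core is unreadable, and nothing shows how a dimethylamino group behaves with the furan substituent. The expectation is that compound 4 remains at the limit, the step of a number no higher from compound 3 to compound 4 (the limit leaves the size open) being an estimate without measured support. Compound 4 is estimated at 20000 nM, expected between 5000 nM and 50000 nM.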

Compound 4, half-maximal inhibitory concentration: > 20000 nM
Compound 4 ended at the assay's limit; the forecaster's own chance of this, stated with the estimate: 70%; the middle value sits exactly at the limit.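

With furan-3-yl on the shared core, dimethylamino joins methoxy and methylamino at the limit of this assay: the limit of > 20000 nM in this assay, at which 3 of the 4 values shown sit. The steps among compound 2, compound 3 and compound 4 cannot be read, as all three values are limits. Among these compounds, with dimethylamino held in place, the one readable step is an at least 83-fold higher number from compound 1 to compound 4 (1.92 log units; beyond the scatter), for furan-3-yl in place of ethynyl on an aromatic carbon, so dimethylamino at this position does not by itself keep a compound measurable in this assay.

Going by these compounds, how the methoxy, methylamino and dimethylamino groups rank on the furanyl core remains open, with no number for any of the three. Also open, on these data alone, is whether an unsubstituted amino group in this position, or a methyl group in place of the furan-3-yl, would bring a value back into the measurable range.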